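The source may hold more compounds than are shown below. What is called first, only, known or untested is meant among the compounds shown, and "the series" means these compounds.

Compound 1, `CCN(CC)c1ccc2cc(C(=O)c3ccc(N4CCN(C(=O)CN5CCNCC5)CC4)cc3)oc2c1`, is one of a pair of close analogues built on the same core and tested in a functional assay on MCF7 cells (Homo sapiens) for cytotoxicity, read by MTT assay, with a stated time of 48 h; a lower number here means a stronger inhibitor, a higher number a weaker inhibitor. In this assay, for the measured compounds named here, compound 1 gives 5340 nM, which is the only actual number in this small set. Compound 2, `CCN(CC)c1ccc2cc(C(=O)c3ccc(N4CCN(C(=O)CN5CCN(S(=O)(=O)c6ccc(C#N)cc6)CC5)CC4)cc3)oc2c1`, carries a (4-cyanophenyl)sulfonyl group where compound 1 has a hydrogen on an amine nitrogen in a ring. In this assay compound 2 gives > 40000 nM, a limit of the assay and not a number. That single change gives an at least 7.4-fold higher number from compound 1 to compound 2 (0.87 log units; beyond the scatter), a weakening that is at least modest, because compound 2 sits at the limit of > 40000 nM in this assay, at which 1 of the 2 values shown sits.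

Compound 3, `CCOC(=O)CN1CCN(CC(=O)N2CCN(c3ccc(C(=O)c4cc5ccc(N(CC)CC)cc5o4)cc3)CC2)CC1`, is not yet measured. It differs from compound 1 in one place: (ethoxycarbonyl)methyl in place of hydrogen on an amine nitrogen in a ring. Going by the values given here, the only measured step on this same nitrogen is the one to compound 2, and it weakened the compound. A different group enters at the same nitrogen here, so the direction is expected to be the same, though the size is uncertain. Compound 3 is therefore expected to give 11000 nM, somewhere between 4000 nM and 35000 nM. That corresponds to an expected step of a 2.1-fold higher number from compound 1 to compound 3 (0.31 log units; beyond the scatter).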

Compound 3, half-maximal inhibitory concentration: > 40000 nM
Compound 3: only a limit was reported; the forecaster's own chance of this, stated with the estimate: 20%; at least 3.6-fold (0.56 log units) between middle value and limit.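

Compound 3 shows that the loss on this amine nitrogen does not belong to the (4-cyanophenyl)sulfonyl group alone: putting (ethoxycarbonyl)methyl, a group with no ring, in place of the hydrogen also weakens the compound in this assay, with an at least 7.4-fold higher number from compound 1 to compound 3 (0.87 log units; beyond the scatter). Two quite different groups at this position now both give a weaker result than the hydrogen of compound 1, and neither compound shown goes against this. In this assay compound 3 gives > 40000 nM, a limit of the assay and not a number, and the step between compound 2 and compound 3 cannot be read, so these two groups cannot be ranked against each other: the limit of > 40000 nM in this assay, at which 2 of the 3 values shown sit.

As far as these compounds go, what stays open is whether any group on this nitrogen can match or improve on compound 1, which gives 5340 nM, for example a single methyl, a short chain ending in an amine, or a carboxylic acid in place of the ethyl ester of compound 3. From the compounds shown here alone, how much weaker compound 2 and compound 3 truly are also remains unknown.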